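The source may report more compounds than this note shows. Statements on the series, on what has been measured and on what is new or still open speak of the compounds shown alone.

Working notes on the series. Compound 1 `C[C@H]1CC(Cl)=C([Si](C)(C)C)[C@@H](C2CCCCC2)O1` gives 33000 nM in a functional assay on WiDr cells (Homo sapiens) for antiproliferative activity; on this read-out lower numbers stand for stronger inhibition of growth and higher numbers for weaker inhibition of growth. Going by the values given here, compound 2 `CC[C@H]1CC(Cl)=C([Si](C)(C)C)[C@@H](C2CCCCC2)O1` gives 73000 nM in this assay, the highest of the two numbers so far; the only measured step, a 2.2-fold higher number from compound 1 to compound 2 (0.34 log units; beyond the scatter), is modest. Compound 3 `C[Si](C)(C)C1=C(Cl)C[C@H](C2CCCCC2)O[C@@H]1C1CCCCC1` carries cyclohexyl in place of ethyl on a saturated ring carbon. Among the compounds with values here, only that one step bears on the change, and it points to a somewhat higher number as carbon is added at this position, so a modest rise is expected rather than no change. Compound 3 is estimated at 120000 nM (range 35000 nM to 400000 nM), an expected step of a 1.6-fold higher number from compound 2 to compound 3 (0.22 log units; within the scatter).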

Compound 3, concentration for total growth inhibition: 81000 nM
For compound 3 the middle estimate is 1.5-fold (0.17 log units) above the measured one; measured number inside the range.
By their numbers in this assay, from the lowest: compound 1; then compounds 2 and 3 (each within the scatter of the next).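

With cyclohexyl in place of ethyl on this saturated ring carbon, this assay shows a 1.1-fold higher number from compound 2 to compound 3 (0.05 log units; within the scatter) as a step within the scatter, so the rise seen on going from methyl to ethyl does not continue. Cyclohexyl in place of methyl gives a 2.5-fold higher number from compound 1 to compound 3 (0.39 log units; beyond the scatter) and so still separates compound 3 from compound 1, leaving compound 1 alone apart from the other two. No measurement at hand explains this levelling. On these data alone, whether a hydroxyl, an amine or a carboxylic acid on this carbon would shift the number remains open, as does the effect of a phenyl ring or a longer chain.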